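From cyclohexyl to cyclopentyl on the shared core

The compounds below may be only part of what the source reports. "The series", "measured", "known", "first", "only" and "open" are said of these compounds alone.

In a functional assay on HeLa cells (Homo sapiens) for cytotoxicity, read by MTT assay, with a stated time of 72 h (a higher number here means a weaker inhibitor, a lower number a stronger inhibitor), compound 1 (`COc1ccc(C(=O)n2c(CC(C)C)nc3ccccc32)cc1`) gives > 10000 nM as a limit of the assay, not a number. Compound 2 (`COc1ccc(C(=O)n2c(C3CCCCC3)nc3ccccc32)cc1`) likewise gives > 10000 nM as a limit only, so it has no numerical position in the series. Within the data shown here, the one measured step is a step that the two limits leave unreadable from compound 1 to compound 2 and offers no size to carry forward. The evidence so far is the limit of > 10000 nM in this assay, at which 2 of the 2 values shown sit, and sets no trend.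

Compound 3 (`COc1ccc(C(=O)n2c(C3CCCC3)nc3ccccc32)cc1`) carries cyclopentyl in place of cyclohexyl on an aromatic carbon and keeps the rest of the structure. With no readable step to draw on, no shift beyond the scatter is expected in this assay and no direction can be argued. The expected change is a step that the limit leaves unreadable from compound 2 to compound 3 and another limit is the likeliest report. Compound 3 is estimated at 15000 nM (expected range 5000 nM to 50000 nM).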

Compound 3, half-maximal inhibitory concentration: > 10000 nM
Compound 3 ended at the assay's limit (the forecaster's own chance of this, stated with the estimate: 80%); the middle value is on the limit's open side.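

In this assay, among these compounds, compound 3 gives > 10000 nM, a limit and not a number, and no step among compound 1, compound 2 and compound 3 can be read. The compounds shown leave open whether any group at this place on the shared core gives a measurable value.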